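Will Inverting One Stereocentre Lower Compound 4 Too?

This account rests on a few compounds, and the source may have more. Where it says the series, first, only, none or still open, it means among the compounds named here.

In an ADME assay on microsomes from liver (Rattus norvegicus) for metabolic stability, using NADPH, with a stated time of 10 min (a lower number here means that less of the compound is left, a higher number that more of the compound is left), compound 3 `NCCCCN(C[C@H]1Cc2nccnc2CN1)[C@H]1CCCc2cccnc21` gives 50% remaining, level within the scatter with compound 1 `NCCCCN(C[C@H]1Cc2cccnc2CN1)[C@H]1CCCc2cccnc21` at 49% remaining, while compound 2 `NCCCCN(C[C@@H]1Cc2cccnc2CN1)[C@H]1CCCc2cccnc21` stands at 37% remaining, a gap beyond the scatter. Compound 4 `NCCCCN(C[C@@H]1Cc2nccnc2CN1)[C@H]1CCCc2cccnc21` is related to compound 3 as follows: the two compounds have the same atoms and bonds and differ only in configuration as drawn: 1 of 2 stereo elements differ; a stereocentre at a saturated ring carbon is drawn R in compound 3 and S in compound 4 and nothing else. Going by the values given here, the only guide is the fact that compounds 1 and 2 differ only in the configuration as drawn and that same switch from R to S gave a number 12 percentage points lower from compound 1 to compound 2 (beyond the scatter) in this pair. On this single pair, a drop of similar size is expected, so the estimated change is a number 12 percentage points lower from compound 3 to compound 4 (beyond the scatter) in this assay here. Compound 4 is therefore estimated at 38% remaining, with an expected range from 26% to 50% given so little evidence.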

Compound 4, percent of the compound remaining: 67%
Compound 4: middle estimate off by 29 percentage points, on the low side; measured number outside the range, above it.
By their numbers in this assay, from the lowest: compound 2; then compounds 1 and 3 (each within the scatter of the next); then compound 4.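

In this assay, the switch from R to S at this saturated ring carbon gives a number 17 percentage points higher from compound 3 to compound 4 (beyond the scatter), whereas the same switch gave a number 12 percentage points lower from compound 1 to compound 2 (beyond the scatter). The change therefore has no fixed direction across these two pairs, and its outcome differs with the rest of the molecule. The rise in the second pair can only come from the configuration, because nothing else changes: the fact that compounds 3 and 4 differ only in the configuration as drawn

As far as these compounds go, what makes the two pairs go opposite ways stays open. So does the direction of this switch with a carboxylic acid in place of the amine.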